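Aryl-triazole diaryl ureas: ortho substituent swap

The compounds below may be only part of what the source reports. "The series", "measured", "known", "first", "only" and "open" are said of these compounds alone.

The series shares a diaryl urea core carrying a triazolylmethoxy arm, with the triazole bearing a substituted phenyl. Compound 1 `CC(C)c1ccccc1-n1cc(COc2cccc(NC(=O)Nc3ccc(Cl)c(C(F)(F)F)c3)c2)nn1` carries isopropyl on that phenyl; in a functional assay on HepG2 cells (Homo sapiens) for inhibition, read by MTT assay, with a stated time of 72 h (a lower number here means a stronger inhibitor, a higher number a weaker inhibitor), compound 1 gives 1900 nM. Compound 2 `O=C(Nc1cccc(OCc2cn(-c3ccccc3I)nn2)c1)Nc1ccc(Cl)c(C(F)(F)F)c1` carries iodo in the same place, and in this assay compound 2 gives 2870 nM. Among the compounds with values here, the only step recorded, a 1.5-fold higher number from compound 1 to compound 2 (0.18 log units; within the scatter), is within the scatter, so compounds 1 and 2 cannot be ordered on these numbers; compound 2 simply holds the higher of the two values, with compound 1 as its nearest neighbour.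

Compound 3 `COc1ccccc1-n1cc(COc2cccc(NC(=O)Nc3ccc(Cl)c(C(F)(F)F)c3)c2)nn1` is the next member. Relative to compound 2 the change is methoxy in place of iodo on an aromatic carbon. Within the data shown here, the one step that bears on this position, from isopropyl to iodo, moved the number by less than the scatter, and no other step is available. On that basis the step from compound 2 to compound 3 is expected to be small, a 1.1-fold lower number from compound 2 to compound 3 (0.06 log units; within the scatter), with no direction beyond the scatter. For compound 3 the estimate in this assay is 2500 nM, expected to fall between 1000 nM and 6500 nM.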

Compound 3, half-maximal inhibitory concentration: 11300 nM
Estimate against measurement, compound 3: 4.5-fold (0.66 log units) below, and the stated range ends below it.
By their numbers in this assay, from the lowest: compounds 1 and 2 (each within the scatter of the next); then compound 3.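

In this assay, the substituent on this aromatic carbon is no longer shown to be interchangeable: the change to methoxy gives a 3.9-fold higher number from compound 2 to compound 3 (0.60 log units; beyond the scatter) from iodo and a 5.9-fold higher number from compound 1 to compound 3 (0.77 log units; beyond the scatter) from isopropyl, both beyond the scatter, whereas the exchange of isopropyl for iodo, a 1.5-fold higher number from compound 1 to compound 2 (0.18 log units; within the scatter), stayed within it. Compound 3 therefore separates from compounds 1 and 2, which still cannot be ordered against each other, and the three compounds show that a change at this position can move the number even though the first pair did not. Methoxy enters with 1 hydrogen-bond acceptor where iodo has 0, but no measurement here links that count, or any other feature of the group, to the higher number.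

As far as these compounds go, whether the higher number is particular to methoxy, or also appears with a hydroxyl, an ethoxy or an amine at this position, remains open. Also open, from the compounds shown here alone, is where a small group such as fluoro, or hydrogen itself, would stand relative to compounds 1, 2 and 3.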